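This account rests on a few compounds, and the source may have more. Where it says the series, first, only, none or still open, it means among the compounds named here.

Measured so far:
Compound 1, `COc1cc(NC(=O)Nc2cc(Nc3ccc(C)c(F)c3)ncn2)cc(OC)c1`: 30.6%
Compound 2, `COc1cc(Nc2cc(NC(=O)Nc3c(Cl)cccc3Cl)ncn2)cc(C(F)(F)F)c1`: 23.1%

Both numbers come from a functional assay on NCI-H520 cells (Homo sapiens) for inhibition, read by MTT assay, with a stated time of 48 h, tested at 10 uM; on this read-out higher numbers stand for more inhibition at the one concentration tested (going by the name of the read-out) and lower numbers for less inhibition. Compound 1 holds the highest of the two numbers, and compound 2 is the nearest to it, yet the gap between compound 1 and compound 2 lies within the usual scatter of repeated measurements, so the two cannot be ranked against each other on these values. For the measured compounds named here, no pair of measured compounds differs in only one place, so no single structural change has a measured effect in this set.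

Compound 3, `COc1cc(NC(=O)Nc2cc(Nc3cc(F)ccc3OC)ncn2)cc(OC)c1`, has not yet been measured in this assay. It differs from compound 1 in one place: 5-fluoro-2-methoxyphenyl in place of 3-fluoro-4-methylphenyl on a nitrogen on an aromatic ring. Going by the values given here, the only foothold for an expectation is the value of compound 1, since the change itself has no measured counterpart here. With nothing to lean on, the expected step is small, in no fixed direction, and quite possibly none beyond the scatter. The step expected is a number 2.6 percentage points lower from compound 1 to compound 3 (within the scatter). Compound 3 is estimated to give 28%, with a range from 10% to 46%.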

Compound 3, a percentage reported as inhibition, at one concentration (the size of the read-out at that concentration, not a potency): 38%
The estimate for compound 3 lay 10 percentage points below the measured number, within the range that was stated.
By their numbers in this assay, from the lowest: compounds 2, 1 and 3 (each within the scatter of the next, the first and the last beyond it).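

For the compounds shown here, exchanging 3-fluoro-4-methylphenyl for 5-fluoro-2-methoxyphenyl on a nitrogen on an aromatic ring gives the first measured single-place step in this set, and in this assay it reads a number 7.4 percentage points higher from compound 1 to compound 3 (within the scatter) as the result of that exchange. This step cannot be called a gain or a loss, but it does show that this place accepts a second substituted phenyl ring, one carrying a methoxy group and a hydrogen-bond acceptor that the leaving group lacks, without a difference that stands clear of the usual scatter of repeated measurements. No other measurement here bears on why the two groups read alike.

The exchange alters the methyl-to-methoxy choice and the placing of the fluorine together, so the compounds shown cannot assign any part of the step to either alteration, and a reading taken at one concentration says nothing about potency. Also open, from the compounds shown here alone, is how this place would respond to a group of a different kind, such as a morpholine, a primary amine or a carboxylic acid, in place of the substituted phenyl ring.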